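Swapping trifluoromethyl for fluoro on the phenyl ring

The source may report more compounds than this note shows. Statements on the series, on what has been measured and on what is new or still open speak of the compounds shown alone.

Measured compounds:
Compound 1 `CC1=C(/C=C/C(=O)/C=C/c2ccccc2F)C(C)(C)CCC1` gives 22100 nM in a functional assay on PC-3 cells (Homo sapiens) for cytotoxicity, read by MTT assay, with a stated time of 72 h; on this read-out higher numbers stand for weaker inhibition and lower numbers for stronger inhibition.
Compound 2 `CC1=CCCC(C)(C)C1/C=C/C(=O)/C=C/c1ccccc1C(F)(F)F` gives 19000 nM in this assay.
Compound 3 `CC1=CCCC(C)(C)C1/C=C/C(=O)/C=C/c1ccc(C(F)(F)F)cc1` gives 7900 nM in this assay.

Among these three numbers compound 2 stands second highest. Its nearest neighbour is compound 1, whose number is within the scatter of it; compound 3 lies furthest away, with a lower number beyond the scatter.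

Compound 4 `CC1=CCCC(C)(C)C1/C=C/C(=O)/C=C/c1ccccc1F` has not been measured. Its change from compound 2 is fluoro in place of trifluoromethyl on an aromatic carbon. Compound 1 carries the same fluoro group on a slightly different core and gives 22100 nM, so a number in that region is expected for compound 4. The expected step of a 1.1-fold higher number from compound 2 to compound 4 (0.04 log units; within the scatter) should stay within the scatter, in no clear direction. Compound 4 is estimated at 21000 nM, with a range from 9000 nM to 50000 nM.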

Compound 4, half-maximal inhibitory concentration: 4800 nM
For compound 4 the middle estimate is 4.4-fold (0.64 log units) above the measured one; the measured number lies below the stated range.
By their numbers in this assay, from the lowest: compounds 4 and 3 (each within the scatter of the next); then compounds 2 and 1 (each within the scatter of the next).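

In this assay the group on this aromatic carbon clearly matters on the shared core: the swap gives a 4.0-fold lower number from compound 2 to compound 4 (0.60 log units; beyond the scatter) and so goes with stronger inhibition. Compound 1 gives 22100 nM with the same fluoro on its slightly different core and compound 4 gives 4800 nM on the shared core, so a fluoro result does not simply carry over from one core to the other.

Going by these compounds, how a methoxy group or an amine on this carbon would compare remains open. Nothing available explains the step.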